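A few compounds are considered here, and "the series" means these few. Any claim that something is new, unique, unknown or untested is made for them only; others in the source may bear on it.

compound 1 `CC1(C)[C@H]2CC[C@]1(C)N(Cc1cn(-c3ccccc3C#N)nn1)C(=O)C2` gives 180 nM
compound 2 `CC1(C)[C@H]2CC[C@]1(C)N(Cc1cn(-c3ccccc3)nn1)C(=O)C2` gives 90 nM

In a functional assay on HepG2 cells (Homo sapiens) for inhibition, read by MTT assay, with a stated time of 24 h (on this read-out higher numbers stand for weaker inhibition and lower numbers for stronger inhibition), compound 2 gives 90 nM and lies within the usual scatter of compound 1, so the two cannot be ranked. Compound 3 `Cc1ccccc1-n1cc(CN2C(=O)C[C@@H]3CC[C@@]2(C)C3(C)C)nn1` has methyl in place of hydrogen on an aromatic carbon, ortho to a large group (methyl in place of hydrogen on an aromatic carbon). Among the compounds with values here, only one measured step bears on this ring (a 2.0-fold lower number from compound 1 to compound 2 (0.30 log units; within the scatter)), hydrogen in place of cyano, and it stays within the scatter. No step beyond the scatter is therefore expected in this assay for this change, and the estimated step is small (a 1.3-fold higher number from compound 2 to compound 3 (0.12 log units; within the scatter)). Compound 3 is expected at 120 nM with an estimated range of 50 nM to 300 nM for now.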

Compound 3, half-maximal inhibitory concentration: 150 nM
Compound 3: middle estimate off by 1.3-fold (0.10 log units), on the low side; the range from low to high includes it.
By their numbers in this assay, from the lowest: compounds 2, 3 and 1 (each within the scatter of the next).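

In this assay the methyl on this aromatic carbon, ortho to a large group, gives no step beyond the scatter (a 1.7-fold higher number from compound 2 to compound 3 (0.22 log units; within the scatter)). Methyl in place of cyano also stays within the scatter (a 1.2-fold lower number from compound 1 to compound 3 (0.08 log units; within the scatter)), so hydrogen, cyano and methyl cannot be ranked at this position. No measurement here explains this result. Still open, on these data alone, is whether an amine, a carboxylic acid or a longer chain at this position would move the number beyond the scatter. Also open, as far as these compounds go, is whether methyl would behave the same way elsewhere on this ring.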